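The compounds below may be only part of what the source reports. "The series", "measured", "known", "first", "only" and "open" are said of these compounds alone.

Measured compounds in a functional assay on UACC-257 cells (Homo sapiens) for inhibition, read by sulforhodamine B assay, with a stated time of 48 h; on this read-out higher numbers stand for weaker inhibition of growth and lower numbers for stronger inhibition of growth:
compound 1 `COc1ccc(-c2cc(/C=C/C(=O)c3ccc(N)cc3)[nH]n2)cc1`: 4210 nM
compound 2 `COc1ccc(-c2cc(/C=C/C(=O)c3ccc(N)cc3)[nH]n2)cc1OC`: 19500 nM
compound 3 `COc1cc(C(=O)/C=C/c2cc(-c3cc(OC)c(OC)c(OC)c3)n[nH]2)cc(OC)c1OC`: 2990 nM

Compound 2 and compound 1 differ by one change, (hydrogen in place of methoxy on an aromatic carbon), and that change gave a 4.6-fold lower number from compound 2 to compound 1 (0.67 log units; beyond the scatter). The difference between the core of compound 3 and the core of compound 2 is not broken down here. Compound 3 gives the lowest of the three numbers, within the scatter of compound 1 and beyond the scatter from compound 2.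

Compound 4 `COc1ccc(-c2cc(/C=C/C(=O)c3cc(OC)c(OC)c(OC)c3)[nH]n2)cc1OC` is not yet measured. It differs from compound 3 by hydrogen in place of methoxy on an aromatic carbon. This is the same kind of change as that from compound 2 to compound 1, not the same: here the carbon is also meta to a methoxy group (2 heavy atoms). The step from compound 3 to compound 4 in this assay is expected to be a 2.5-fold lower number from compound 3 to compound 4 (0.40 log units; beyond the scatter), resting on a 4.6-fold lower number from compound 2 to compound 1 (0.67 log units; beyond the scatter), with a smaller size allowed for the changed surroundings. Compound 4 is expected to give 1200 nM in this assay, estimated between 400 nM and 4000 nM.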

Compound 4, concentration for total growth inhibition: 3800 nM
For compound 4 the middle estimate is 3.2-fold (0.50 log units) below the measured one; low and high end bracket the measured number.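

In this assay, hydrogen in place of methoxy on an aromatic carbon gives a 1.3-fold higher number from compound 3 to compound 4 (0.10 log units; within the scatter), so the size of the step seen on the core of compound 2 does not carry over to the core of compound 3. The two cores answer differently to this change: the same change on two cores in this assay, a 4.6-fold lower number (0.67 log units; beyond the scatter) from compound 2 to compound 1 and a 1.3-fold higher number (0.10 log units; within the scatter) from compound 3 to compound 4, 5.9-fold (0.77 log units) apart, beyond the scatter of two such steps

With a single pair on each core, this does not show which difference between the cores goes with the gap, nor which step a further core would follow. As far as these compounds go, whether a hydroxyl, a fluorine or an amine on this carbon would follow either step stays open. Also open, from the compounds shown here alone, is whether the gap between the two steps holds on any read-out other than this assay.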